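Aminocyclohexyl bromo-naphthyridine carboxamides: amide substituent variation

The source may report more compounds than this note shows. Statements on the series, on what has been measured and on what is new or still open speak of the compounds shown alone.

Compound 3 `N[C@H]1CC[C@H](Nc2c(C(=O)NCc3ccc(Cl)cc3Cl)nc(Br)c3cccnc23)CC1` gives 5000 nM in a functional assay on HEY cells (Homo sapiens) for cytotoxicity, read by MTT assay, with a stated time of 72 h; a lower number here means a stronger inhibitor, a higher number a weaker inhibitor. It holds the lower of the two numbers in the set, but compound 1 `N[C@H]1CC[C@H](Nc2c(C(=O)NCc3ccc(Oc4ccccc4)cc3)nc(Br)c3cccnc23)CC1`, at 9000 nM, lies within the scatter of it, so no order between the two is claimed. Compound 2 `N[C@H]1CC[C@H](Nc2c(C(=O)NCc3ccco3)nc(Br)c3cccnc23)CC1` reaches only the assay limit of > 10000 nM, which is a limit and not a number; the limit of > 10000 nM in this assay, at which 1 of the 3 values shown sits, applies to it.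

Compound 4 `COc1ccc(CNC(=O)c2nc(Br)c3cccnc3c2N[C@H]2CC[C@H](N)CC2)cc1` differs from compound 3 at the amide side: 4-methoxyphenyl in place of 2,4-dichlorophenyl on a saturated chain carbon bound to an amide-type nitrogen

Among the compounds with values here, only one measured step touches this position: an at least 2.0-fold lower number from compound 2 to compound 3 (0.30 log units; that floor lies within the scatter), and its floor lies within the scatter, so it gives no firm direction for an exchange of one aryl group for another. Within the data shown here, the three numbers in hand sit close together, and the change from 2,4-dichlorophenyl to 4-methoxyphenyl has no precedent within the set. A step of a 1.4-fold higher number from compound 3 to compound 4 (0.15 log units; within the scatter) is therefore expected, with the number most likely staying within the scatter of compound 3, and with a real chance that compound 4 reports only a limit. Compound 4 is estimated at 7000 nM, with a range from 3000 nM to 16000 nM.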

Compound 4, half-maximal inhibitory concentration: 4000 nM
Compound 4: the middle estimate sits 1.8-fold (0.24 log units) above what was measured, and the stated range covers the measured number.
By their numbers in this assay, from the lowest: compounds 4, 3 and 1 (each within the scatter of the next, the first and the last beyond it). At a limit, above all of these: compound 2.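

In this assay, the exchange of 2,4-dichlorophenyl for 4-methoxyphenyl on a saturated chain carbon bound to an amide-type nitrogen gives a 1.3-fold lower number from compound 3 to compound 4 (0.10 log units; within the scatter), so these two aryl groups cannot be told apart at this position. Steps beyond the scatter at this position appear only with compound 4: a 2.3-fold lower number from compound 1 to compound 4 (0.35 log units; beyond the scatter), where methyl replaces phenyl on the oxygen, and an at least 2.5-fold lower number from compound 2 to compound 4 (0.39 log units; beyond the scatter), where 4-methoxyphenyl replaces furan-2-yl and the size printed is only a floor. Compound 2 holds a limit and not a number, so that second step gives a direction and no exact size: the limit of > 10000 nM in this assay, at which 1 of the 4 values shown sits.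

Still open, as far as these compounds go, is whether a carboxylic acid on the phenyl ring of the 4-methoxybenzyl group, or a longer chain on the amide-type nitrogen, would shift the number beyond the scatter of compound 4. The shared core and its aminocyclohexyl group stay the same in all four compounds shown, so these results say nothing about how a chlorine or a nitrile in place of the bromo group would read in this assay.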